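Aminoquinoline cinnamamides: branching at the alkyl substituent

The source may report more compounds than this note shows. Statements on the series, on what has been measured and on what is new or still open speak of the compounds shown alone.

Measured compounds in an assay on isolated protein for displacement of a labelled ligand from melanin-concentrating hormone receptor 1 (Homo sapiens); on this read-out higher numbers stand for weaker inhibition and lower numbers for stronger inhibition:
compound 1 `CCCc1cc(N)c2cc(NC(=O)/C=C/c3ccc(C(C)(C)C)cc3)ccc2n1` gives 22 nM
compound 2 `CCCc1cc(N)c2cc(NC(=O)/C=C/c3ccc(C(C)C)cc3)ccc2n1` gives 2.9 nM
compound 3 `CC(C)c1cc(N)c2cc(NC(=O)/C=C/c3ccc(C(F)(F)F)cc3)ccc2n1` gives 2.1 nM

Compound 3 gives the lowest number of the three. Its value and that of compound 2 lie within the scatter of each other, so no order between them is claimed. The difference between the core of compound 3 and the core of compound 2 is not broken down here.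

Among the compounds with values here, the one counted step among the measured compounds is methyl in place of hydrogen on a saturated chain carbon bound to an aromatic carbon and two saturated chain carbons; it reads a 7.6-fold higher number from compound 2 to compound 1 (0.88 log units; beyond the scatter).

Compound 4 `CCC(C)c1cc(N)c2cc(NC(=O)/C=C/c3ccc(C(F)(F)F)cc3)ccc2n1` has not been measured. Relative to compound 3 it carries methyl in place of hydrogen on a saturated chain carbon, two bonds along the chain from an aromatic carbon. This is the same kind of change as that from compound 2 to compound 1, but at a different place: there the carbon was bound to an aromatic carbon and two saturated chain carbons, here it is two bonds along the chain from an aromatic carbon.

The expectation for compound 4 in this assay rests on the step from compound 2 to compound 1, which was a 7.6-fold higher number from compound 2 to compound 1 (0.88 log units; beyond the scatter), taken as a guide to a weakening of smaller size given the different place. Compound 4 is expected to come in at 6 nM, between 2 nM and 20 nM, which means an estimated step of a 2.9-fold higher number from compound 3 to compound 4 (0.46 log units; beyond the scatter).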

Compound 4, half-maximal inhibitory concentration: 0.3 nM
Compound 4: middle estimate off by 20-fold (1.30 log units), on the high side; measured number below the stated range.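

In this assay, methyl in place of hydrogen on a saturated chain carbon, two bonds along the chain from an aromatic carbon, gives a 7.0-fold lower number from compound 3 to compound 4 (0.85 log units; beyond the scatter), and set beside the earlier step the same kind of change runs in the opposite direction: the same change on two cores in this assay, a 7.6-fold higher number (0.88 log units; beyond the scatter) from compound 2 to compound 1 and a 7.0-fold lower number (0.85 log units; beyond the scatter) from compound 3 to compound 4, 53-fold (1.73 log units) apart, beyond the scatter of two such steps. Within this series, then, the direction of the step seen on one core and at one place gives no safe guide to the direction of the step on another core or at another place. Within the data shown here, the comparison does not show which difference matters, since the two steps differ both in the place of the change and in the rest of the molecule, and with only one step at each place these cannot be separated.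

The compounds shown leave open whether the lower number extends to a longer chain, such as n-butyl, or to tert-butyl in place of the sec-butyl group of compound 4. They also leave open whether isopropyl to sec-butyl reads the same way when the rest of the molecule is that of compound 2.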